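Replacing chloro with amino in compound 1

The compounds below may be only part of what the source reports. "The series", "measured", "known", "first", "only" and "open" are said of these compounds alone.

Measured so far in a physicochemical assay for lipophilicity, read by spectrophotometry, measured as octanol-water partition, at pH 7.4 (on this read-out lower numbers stand for lower lipophilicity and higher numbers for higher lipophilicity), are three compounds
- Compound 1 `CCOc1cc(CN2CCC(NC(=O)c3ccc(Cl)nc3)CC2)cc(OCC)c1-c1ccc(F)cc1` gives 3.55
- Compound 2 `CCOc1cc(CN2CCC(NC(=O)c3cncc(C)c3)CC2)cc(OCC)c1Cl` gives 3.43
- Compound 3 `CCOc1cc(CN2CCC[C@H](NC(=O)c3cncc(C)c3)CC2)ccc1Cl` has the entry "not determined" (no result reported) and no number

In this assay compound 1 stands with 3.55 level with compound 2 at 3.43 as these two numbers lie within the usual scatter of each other. Compound 3 adds no number to the comparison.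

Compound 4 `CCOc1cc(CN2CCC(NC(=O)c3ccc(N)nc3)CC2)cc(OCC)c1-c1ccc(F)cc1` differs from compound 1 in one place amino in place of chloro on an aromatic carbon and carries amino in place of chloro on an aromatic carbon, next to the ring nitrogen. The 6-chloropyridin-3-yl group thereby becomes 6-aminopyridin-3-yl, and the rest of the core of compound 1 stays the same.

Within the data shown here, no two measured compounds differ in only one place, so the data hold no measured step for this change. The expectation rests on the structural change alone: chloro leaves with no hydrogen-bond donor or acceptor, and amino enters with one of each. A step towards lower numbers in this assay is expected, larger than the scatter. The estimated change is a number 0.95 log units lower from compound 1 to compound 4 (beyond the scatter) for this replacement. In this assay compound 4 is estimated at 2.6 with an expected range from 2.1 to 3.1 for the measurement.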

Compound 4, distribution coefficient: 3.15
Compound 4: middle estimate off by 0.55 log units, on the low side; measured number outside the range, above it.
By their numbers in this assay, from the lowest: compounds 4, 2 and 1 (each within the scatter of the next, the first and the last beyond it).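

In this assay, among these compounds, the change from the 6-chloropyridin-3-yl group to the 6-aminopyridin-3-yl group gives the first step between two compounds that differ in one place: a number 0.40 log units lower from compound 1 to compound 4 (beyond the scatter) with the rest of the core of compound 1 unchanged. The earlier compounds shown here could not show this, since they differ from one another in more than one place, and this step now shows that the read-out responds to a change at this aromatic carbon next to the ring nitrogen, although the step is only modest for chloro, with no hydrogen-bond donor or acceptor, giving way to amino, with one of each. Nothing in the data shown accounts for the size of this step.

The compounds shown leave open how this assay would respond to methylamino, dimethylamino, hydroxyl or methoxy at this same place, so a single pair cannot yet define a trend across groups. From the compounds shown here alone, it also remains open whether amino in place of chloro would give a step of similar size on another core, such as that of compound 2, where a chloro group replaces the 4-fluorophenyl group.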